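A few compounds are considered here, and "the series" means these few. Any claim that something is new, unique, unknown or untested is made for them only; others in the source may bear on it.

In a functional assay on BV-2 cells (Mus musculus), read by Griess assay, with a stated time of 24 h (a higher number here means a weaker inhibitor, a lower number a stronger inhibitor), compound 1 `C=C(C)CC1COC2(C=CC(=O)C=C2)N(c2ccccc2)C1=O` gives 450 nM, compound 2 `C=CCCC1COC2(C=CC(=O)C=C2)N(c2ccccc2)C1=O` gives 730 nM, and compound 3 `O=C1C=CC2(C=C1)OCC(Cc1ccccc1)C(=O)N2c1ccccc1` gives 570 nM. Compound 3 cannot be separated from either of the others, as shown by a 1.3-fold higher number from compound 1 to compound 3 (0.10 log units; within the scatter) and a 1.3-fold lower number from compound 2 to compound 3 (0.11 log units; within the scatter).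

Compound 4 `O=C1C=CC2(C=C1)OCC(Cc1cccc(Br)c1)C(=O)N2c1ccccc1` keeps the core of compound 3 and turns its benzyl into 3-bromobenzyl: bromo in place of hydrogen on an aromatic carbon. Among the compounds with values here, no measured compound carries a bromo group, so no measured step tests this change directly. The nearest evidence comes from exchanges of the whole group at the same chain carbon. These include a 1.6-fold higher number from compound 1 to compound 2 (0.21 log units; within the scatter), as well as the two steps to compound 3 given above, and none of them goes beyond the scatter. On that limited basis, no step beyond the scatter is expected in this assay, and no direction can be favoured. The estimated outcome is a 1.1-fold lower number from compound 3 to compound 4 (0.06 log units; within the scatter). Compound 4 is therefore expected to give about 500 nM, within an estimated range of 200 nM to 1200 nM.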

Compound 4, half-maximal inhibitory concentration: 540 nM
The estimate for compound 4 lay 1.1-fold (0.03 log units) below the measured number; low and high end bracket the measured number.
By their numbers in this assay, from the lowest: compounds 1, 4, 3 and 2 (each within the scatter of the next).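

In this assay, within the data shown here, a 1.1-fold lower number from compound 3 to compound 4 (0.02 log units; within the scatter) gives the first reading of a change on the aromatic ring itself: a bromo group on this aromatic carbon, meta to a large group, leaves the number within the scatter. The earlier compounds shown here tested only exchanges of the whole group at the chain carbon, and the 3-bromobenzyl group also stays within the scatter of those groups, with a 1.4-fold lower number from compound 2 to compound 4 (0.13 log units; within the scatter) and a 1.2-fold higher number from compound 1 to compound 4 (0.08 log units; within the scatter) as the steps. No measurement shown speaks to the reason for this outcome.

As far as these compounds go, whether an amine or a carboxylic acid on the same aromatic carbon would also stay within the scatter remains open. So does the outcome of a bromo group on another carbon of this ring, or of any replacement for the phenyl group on the ring nitrogen of the shared core.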